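This account rests on a few compounds, and the source may have more. Where it says the series, first, only, none or still open, it means among the compounds named here.

Measured compounds in an ADME assay on LLC-PK1 cells (Sus scrofa) for permeability; a lower number here means that the compound crosses the layer more slowly, a higher number that the compound crosses the layer faster:
- compound 1, `CCn1c(-c2cnc(C)nc2)nc2c(O[C@H]3CCN(C(=O)C4CC4)C3)ncnc21`, gives 28 10^-6 cm/s
- compound 2, `CCn1c(-c2cnc(C)nc2)nc2c(N[C@H]3CCN(C(=O)C4CCC4)C3)ncnc21`, gives 32 10^-6 cm/s
- compound 3, `CCn1c(-c2ccc(C(F)(F)F)nc2)nc2c(O[C@H]3CCN(C(=O)c4cocn4)C3)ncnc21`, gives 29 10^-6 cm/s

Compound 3 stands second highest of the three numbers, but the three values lie within the scatter of one another: the gap to compound 1 and the gap to compound 2 are both within the usual spread of repeated measurements. For the measured compounds named here, on this set no compound can be separated from the others, and the two changes seen so far across the series (the ring attached to the core and the group on the carbonyl carbon) have left the apparent permeability essentially unchanged.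

Compound 4, `CCn1c(-c2ccc(C(F)(F)F)nc2)nc2c(O[C@H]3CCN(C(=O)[C@H]4C[C@@H](OC)C4)C3)ncnc21`, is not yet measured. It differs from compound 3 in one place: 3-methoxycyclobutyl in place of 1,3-oxazol-4-yl on a carbonyl carbon. Going by the values given here, no step between measured compounds matches this change, so the expectation rests only on the flat picture above. A step in this assay of no more than the scatter is expected, with no clear direction. The estimated step is a 1.0-fold higher number from compound 3 to compound 4 (0.01 log units; within the scatter). For compound 4 the estimate is 30 10^-6 cm/s, with a range from 18 10^-6 cm/s to 48 10^-6 cm/s.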

Compound 4, apparent permeability: 35 10^-6 cm/s
Estimate against measurement, compound 4: 1.2-fold (0.07 log units) below, within the range that was stated.
By their numbers in this assay, from the lowest: compounds 1, 3, 2 and 4 (each within the scatter of the next).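

Among the earlier compounds no pair differed in one place only, so this is the first reading of the group on the carbonyl carbon with the rest of the molecule held fixed. In this assay, 3-methoxycyclobutyl in place of 1,3-oxazol-4-yl gives a 1.2-fold higher number from compound 3 to compound 4 (0.08 log units; within the scatter), so a non-aromatic four-membered carbon ring and a five-membered aromatic ring with 2 hetero atoms are not separated at this place. Nothing available explains the size of this step.

Open, as far as these compounds go, is whether an amine or a carboxylic acid on this carbonyl carbon would give a step beyond the scatter, since neither group in this change carries a net charge or a hydrogen-bond donor. Also open, from the compounds shown here alone, is whether the defined stereocentres of 3-methoxycyclobutyl matter, and whether the step reads the same on the core of compound 1.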